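Swapping Phenyl for Cyclopropyl in a Reductase Inhibitor Series

The source may report more compounds than this note shows. Statements on the series, on what has been measured and on what is new or still open speak of the compounds shown alone.

Measured compounds:
Compound 1 `Cc1nn(C(C)(C)C)c2nc(C3CC3)c(/C=C/[C@@H](O)C[C@@H](O)CC(=O)O)c(-c3ccc(F)cc3)c12`: 4.5%
Compound 2 `CC(C)c1nc2c(c(-c3ccccc3)nn2C)c(-c2ccc(F)cc2)c1/C=C/[C@@H](O)C[C@@H](O)CC(=O)O`: 37%

In an in vivo functional assay on the whole organism for inhibition of 3-hydroxy-3-methylglutaryl-coenzyme A reductase (Rattus norvegicus), at a dose of 0.2 mg/kg by the oral route (a lower number here means a weaker effect, a higher number a stronger effect of the compound at the dose given), compound 2 gives 37%, the higher of the two numbers; compound 1 lies well below it, a gap beyond the scatter. Compound 3 `CC(C)c1nc2c(c(C3CC3)nn2C)c(-c2ccc(F)cc2)c1/C=C/[C@@H](O)C[C@@H](O)CC(=O)O` has not been measured. It differs from compound 2 by cyclopropyl in place of phenyl on an aromatic carbon. Among the compounds with values here, no measured pair shows this change, so the step size is uncertain; a moderate downward step is expected, a number 12 percentage points lower from compound 2 to compound 3 (beyond the scatter), though one within the scatter cannot be excluded. Compound 3 is estimated at 25%, with a range from 5% to 50%.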

Compound 3, a percentage reported as inhibition, in the whole organism at one dose (the size of the read-out at that dose, not a potency): 42.9%
Compound 3: middle estimate off by 17.9 percentage points, on the low side, and the stated range covers the measured number.
By their numbers in this assay, from the lowest: compound 1; then compounds 2 and 3 (each within the scatter of the next).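

In this assay, the change to cyclopropyl in place of phenyl on this aromatic carbon is a number 5.9 percentage points higher from compound 2 to compound 3 (within the scatter). At this position, then, the 3 heavy atoms of a non-aromatic ring stand in for the 6 of an aromatic ring with no shift beyond the scatter at this dose. No evidence at hand bears on why the two groups read alike. From the compounds shown here alone, how an amine or a carboxylic acid on this carbon would read remains open. Going by these compounds, the read-out gives the size of the effect at one dose only, so whether compound 2 and compound 3 also read alike at other doses remains open too.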